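Swapping a Naphthalene Arm for a Thiophene Ring

The source may hold more compounds than are shown below. What is called first, only, known or untested is meant among the compounds shown, and "the series" means these compounds.

Compound 1 `COc1ccc(/C=C/C(=O)/C=C/c2ccc(OCc3cn(CCOc4cc(=O)oc5ccccc45)nn3)c(OC)c2)cc1OC`, compound 3 `COc1cccc(/C=C/C(=O)/C=C/c2ccc(OCc3cn(CCOc4cc(=O)oc5ccccc45)nn3)c(OC)c2)c1` and compound 2 `COc1cc(/C=C/C(=O)/C=C/c2cccc3ccccc23)ccc1OCc1cn(CCCCOc2cc(=O)oc3ccccc23)nn1` were compared in a functional assay on COLO 205 cells (Homo sapiens) for inhibition, read by sulforhodamine B assay, with a stated time of 48 h, tested at 50 uM; on this read-out lower numbers stand for less inhibition of growth and higher numbers for more inhibition of growth at the one concentration tested. Among the compounds with values here, compound 1 gives 80% and compound 3 gives 69%; the only one-place step among the measured compounds is a number 11 percentage points lower from compound 1 to compound 3 (beyond the scatter). Compound 2 gives 50%, the lowest of the three numbers and beyond the scatter from both of the others. Compound 4 `COc1cc(/C=C/C(=O)/C=C/c2cccs2)ccc1OCc1cn(CCCCOc2cc(=O)oc3ccccc23)nn1` differs from compound 2 in one place: thiophen-2-yl in place of naphthalen-1-yl on a double-bonded chain carbon bound to a double-bonded chain carbon. Within the data shown here, no measured step touches this position, so the step between methoxy and hydrogen offers no guide to the direction or size of this swap. The expected step is no change at the digits printed from compound 2 to compound 4 (within the scatter), with wide uncertainty either way. Compound 4 is therefore estimated at 50%, between 25% and 75%.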

Compound 4, percent growth inhibition at one concentration: 40%
Estimate against measurement, compound 4: 10 percentage points above; low and high end bracket the measured number.
By their numbers in this assay, from the lowest: compounds 4 and 2 (each within the scatter of the next); then compound 3; then compound 1.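

In this assay, this position on a double-bonded chain carbon now has a measured step of its own, a number 10 percentage points lower from compound 2 to compound 4 (within the scatter). Thiophen-2-yl, with one five-membered aromatic ring, thus stays within the scatter of naphthalen-1-yl, with two six-membered aromatic rings, although it has fewer heavy atoms. No measurement on hand offers an explanation for this reading.

On these data alone, whether a furan ring or a carboxylic acid would fit this position equally well remains open. So does whether this swap would read the same with the shorter chain of compound 1.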